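Trimming the side chain on compound 3 down to methyl

The compounds below may be only part of what the source reports. "The series", "measured", "known", "first", "only" and "open" are said of these compounds alone.

Measured so far:
Compound 1, `C=CCn1c(=O)n(C2CN(CCCC)CC(CO)O2)c2nc(N)nc(O)c21`: 52%
Compound 2, `CC1(C)O[C@@H]2[C@H](O1)[C@@H](CO)O[C@H]2n1c(=O)n(C/C=C/c2ccccc2)c2c(O)nc(N)nc21`: 10%
Compound 3, `CCOC(=O)Cn1c(=O)n(C2OC(CO)[C@@H](O)[C@H]2O)c2nc(N)nc(O)c21`: 58%

Of the compounds shown here, three sharing one core have been tested in a functional assay on the whole organism with Mus musculus as the target; on this read-out higher numbers stand for larger maximal responses and lower numbers for smaller maximal responses. Compound 3 gives 58%, the highest of the three numbers, yet compound 1 at 52% lies within the usual scatter of it, so the two cannot be ranked against each other. Compound 2, with 10%, sits well beyond the scatter below both.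

Compound 4, `Cn1c(=O)n(C2OC(CO)[C@@H](O)[C@H]2O)c2nc(N)nc(O)c21`, has not yet been measured. Compared with compound 3 it shows one change: hydrogen in place of ethoxycarbonyl on a saturated chain carbon bound to an aromatic nitrogen. No direct comparison of two measured compounds mirrors this change, so the expectation rests only on the values above. Compounds 1 and 3 carry different groups at that position and still land close together, which suggests that this position tolerates variation; compound 2 shows that large changes elsewhere can lower the response strongly.

For compound 4 the step of a number 8 percentage points lower from compound 3 to compound 4 (within the scatter) in this assay is expected to stay within the scatter. Compound 4 is therefore estimated at 50% in this assay, with a range from 30% to 72%.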

Compound 4, largest response reached (reported as maximal response), in percent of the reference or control that the assay uses: 100%
Compound 4: middle estimate off by 50 percentage points, on the low side, and the stated range ends below it.
By their numbers in this assay, from the lowest: compound 2; then compounds 1 and 3 (each within the scatter of the next); then compound 4.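

In this assay, hydrogen in place of ethoxycarbonyl on a saturated chain carbon bound to an aromatic nitrogen brings a number 42 percentage points higher from compound 3 to compound 4 (beyond the scatter). Compounds 1, 2 and 3 differ from one another in more than one place, so none of their comparisons could isolate this position; compound 3 and compound 4 differ in this one place alone, and they show that the group carried here can strongly change the maximal response. Nothing available explains why this change has so large an effect.

The compounds shown leave open whether the higher number depends on the ethoxycarbonyl group itself or on any group larger than hydrogen at this carbon, since this single pair cannot separate the two. A carboxylic acid in place of the ethoxycarbonyl, or an ethyl or longer chain in place of the methyl, would show whether the response falls gradually as the side chain grows or only with particular groups, and whether the same holds on other versions of the shared core.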